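This account rests on a few compounds, and the source may have more. Where it says the series, first, only, none or still open, it means among the compounds named here.

Compound 1 `COc1ccc(-c2cnc(NC(=O)C3CCOCC3)n2C)cc1` sits at the limit > 100000 nM in a toxicity assay on THP-1 cells (Homo sapiens) for inhibition; on this read-out higher numbers stand for lower toxicity in this test and lower numbers for higher toxicity in this test.
Compound 2 `COc1ccc(-c2cnc(NC(=O)c3cccc(F)c3)n2C)cc1` sits at the limit > 100000 nM in this assay.
Compound 3 `COc1ccc(-c2cnc(NC(=O)c3cccc(O)c3)n2C)cc1` sits at the limit > 100000 nM in this assay.

Compound 3 stands at a limit of this assay, as do the two other values, so the limit of > 100000 nM in this assay, at which 3 of the 3 values shown sit, is the whole of the evidence. The three measured steps, a step that the two limits leave unreadable from compound 1 to compound 2, a step that the two limits leave unreadable from compound 1 to compound 3 and a step that the two limits leave unreadable from compound 2 to compound 3, are all unreadable in size. The change now followed is pyridin-4-yl in place of 3-hydroxyphenyl on a carbonyl carbon, giving compound 4 `COc1ccc(-c2cnc(NC(=O)c3ccncc3)n2C)cc1`. No measured step can be read for size, so none gives a direction, and with every value at the limit the expected step of a number no higher from compound 3 to compound 4 (the limit leaves the size open) is again one that cannot be read. Compound 4 is therefore expected to reach the same limit, with an estimate of 100000 nM in this assay and a range of 50000 nM to 200000 nM.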

Compound 4, half-maximal cytotoxic concentration: > 100000 nM
Compound 4 gave a limit, no number (the forecaster's own chance of this, stated with the estimate: 85%); the middle value lies on the limit itself.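

Compound 4 joins compound 1, compound 2 and compound 3 at a limit in this assay, and none of its steps to them can be read in size. The compounds shown leave open how these four differ in this assay, with one limit as the only result: the limit of > 100000 nM in this assay, at which 4 of the 4 values shown sit.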